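The source may hold more compounds than are shown below. What is called first, only, known or untested is meant among the compounds shown, and "the series" means these compounds.

Compound 1 `Nc1ccc(-c2cc(=O)c3c(N)c(F)c(Cl)c(F)c3o2)cc1F` is the reference point of the series. In a functional assay on HeLa cells (Homo sapiens) for cytotoxicity, read by neutral red uptake, with a stated time of 3 days (on this read-out higher numbers stand for weaker inhibition and lower numbers for stronger inhibition), compound 1 gives > 100000 nM, which is a limit of the assay and not a number. Compound 2 `CCCCCCCCCC(=O)OCc1c(F)c(N)c2c(=O)cc(-c3ccc(N)c(F)c3)oc2c1F` likewise gives only a limit in this assay, > 100000 nM. Both results sit at the limit of > 100000 nM in this assay, at which 2 of the 2 values shown sit, so compound 1 stands at a limit with no ranking possible. Compound 3 `CN(C)CCCOCc1c(F)c(N)c2c(=O)cc(-c3ccc(N)c(F)c3)oc2c1F` differs from compound 1 in one place: (3-(dimethylamino)propoxy)methyl in place of chloro on an aromatic carbon. Within the data shown here, no measured step between two compounds exists, so no direction is set; the expectation is no step beyond the scatter, and a limit again seems likely. Compound 3 is estimated at 150000 nM, within 50000 nM to 500000 nM. The expected step is a step that the limit leaves unreadable from compound 1 to compound 3.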

Compound 3, half-maximal inhibitory concentration: 12000 nM
Compound 3: middle estimate off by 13-fold (1.10 log units), on the high side; measured number outside the range, below it.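

In this assay, among these compounds, the position ortho to two fluoro groups gives the first readable number of the series with (3-(dimethylamino)propoxy)methyl in place of chloro: an at least 8.3-fold lower number from compound 1 to compound 3 (0.92 log units; beyond the scatter). Keeping that position substituted, 3-(dimethylamino)propyl in place of nonylcarbonyl on the oxygen gives an at least 8.3-fold lower number from compound 2 to compound 3 (0.92 log units; beyond the scatter), so the group carried on that oxygen matters and not only the presence of a substituent. Both steps are open-ended, and their full sizes cannot be read: the limit of > 100000 nM in this assay, at which 2 of the 3 values shown sit.

From the compounds shown here alone, whether the dimethylamino group or the chain drives the change remains open. A morpholine or a hydroxyl at the chain end would separate the two.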